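The compounds below may be only part of what the source reports. "The series", "measured", "known", "first", "only" and "open" are said of these compounds alone.

Of the compounds shown here, three share one core and have been measured in a functional assay on A549 cells (Homo sapiens) for inhibition, read by CCK-8 assay, with a stated time of 48 h; a higher number here means a weaker inhibitor, a lower number a stronger inhibitor. Compound 1 `Cc1ccc(-c2nn(-c3ccccc3)cc2C(=O)NC(=S)Nc2ccc(Cl)cc2)cc1` gives 3170 nM and stands highest of the three numbers. Compound 3 `Cc1ccc(NC(=S)NC(=O)c2cn(-c3ccccc3)nc2-c2ccc(C)cc2)cc1` gives 2830 nM, and compound 2 `COc1ccc(NC(=S)NC(=O)c2cn(-c3ccccc3)nc2-c2ccc(OC)cc2)cc1` gives 750 nM, so compound 2 sits furthest from compound 1, beyond the scatter, while compound 3 sits nearest to it.

Compound 4 `O=C(NC(=S)Nc1ccc(Cl)cc1)c1cn(-c2ccccc2)nc1-c1ccc(F)cc1` has not yet been measured. It differs from compound 1 in one place: fluoro in place of methyl on an aromatic carbon, on an aromatic carbon of a six-membered aromatic ring of carbon only, para to a large group; read one bond further out, a 4-methylphenyl becomes a 4-fluorophenyl.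

Among the measured compounds shown here, only one measured step changes a single place, a 1.1-fold lower number from compound 1 to compound 3 (0.05 log units; within the scatter), and it swaps a substituent on the other outer ring, not on the one altered here. It shows that a small change at the edge of this series can pass without a shift beyond the scatter. Compound 2 differs from compound 1 in two places, so its lower number cannot be tied to either one alone. For the measured compounds named here, no measured step matches the present change, so for compound 4 a number close to that of compound 1 is expected, with the step of a 1.2-fold lower number from compound 1 to compound 4 (0.09 log units; within the scatter) estimated to stay within the scatter, giving an estimate of 2600 nM in this assay, between 900 nM and 7500 nM.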

Compound 4, half-maximal inhibitory concentration: 2990 nM
Estimate against measurement, compound 4: 1.2-fold (0.06 log units) below; low and high end bracket the measured number.
By their numbers in this assay, from the lowest: compound 2; then compounds 3, 4 and 1 (each within the scatter of the next).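

In this assay, among the compounds shown here, the first measured change on this ring, a 4-methylphenyl becoming a 4-fluorophenyl, gives a 1.1-fold lower number from compound 1 to compound 4 (0.03 log units; within the scatter), so this exchange on an aromatic carbon, para to a large group, moves the number no further than repeated measurements of the same compound might. The earlier single-place step, a 1.1-fold lower number from compound 1 to compound 3 (0.05 log units; within the scatter), concerned the other outer ring, so it said nothing directly about this position; the series now has one step within the scatter at each of these two places, and the methyl and fluoro forms on this ring cannot be ranked against each other in this assay. No measurement shown here gives a reason for this outcome.

Only methyl and fluoro have been compared at this position with everything else held fixed, so this one exchange cannot show how the number would respond to very different groups, such as an amine, a carboxylic acid or a longer chain. As far as these compounds go, it also remains open whether a methoxy on this ring, with the chloro on the other outer ring kept in place, would shift the number beyond the scatter.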